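This account rests on a few compounds, and the source may have more. Where it says the series, first, only, none or still open, it means among the compounds named here.

Measured in an ADME assay on Huh-7 cells (Homo sapiens) for cytotoxicity, with a stated time of 3 days; on this read-out higher numbers stand for lower toxicity in this test and lower numbers for higher toxicity in this test:
Compound 1 `Nc1ccccc1NC(=O)c1c(NO)cc(-c2ccccc2)oc1=O`: > 20000 nM
Compound 2 `O=C(Nc1ccccc1O)c1c(NO)cc(-c2ccccc2)oc1=O`: 14000 nM
Compound 3 `O=C(NC1CCCCC1)c1c(NO)cc(-c2ccccc2)oc1=O`: 10500 nM

The entry for compound 1, > 20000 nM, is a limit of the assay and not a number. The two actual numbers cannot be told apart, with a 1.3-fold lower number from compound 2 to compound 3 (0.12 log units; within the scatter). Against the limit, the picture is an at least 1.9-fold lower number from compound 1 to compound 3 (0.27 log units; that floor lies within the scatter), and likewise an at least 1.4-fold lower number from compound 1 to compound 2 (0.15 log units; that floor lies within the scatter).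

Compound 4 `O=C(NC1CCCCC1)c1c(NO)cc(-c2ccc(F)cc2)oc1=O` carries one change relative to compound 3, fluoro in place of hydrogen on an aromatic carbon, para to a large group, so phenyl becomes 4-fluorophenyl. Within the data shown here, none of the measured steps touches this phenyl group. All three fall on the amide side, so they serve only as a gauge of how little this assay has moved in this small set, and none of them goes beyond the scatter. No shift beyond the scatter is therefore expected, and the anchor is compound 3 at 10500 nM. The estimated change is a 1.1-fold lower number from compound 3 to compound 4 (0.02 log units; within the scatter). Compound 4 is expected at 10000 nM, with an estimated range from 5000 nM to 20000 nM.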

Compound 4, half-maximal cytotoxic concentration: 11400 nM
For compound 4 the middle estimate is 1.1-fold (0.06 log units) below the measured one; the measured number falls inside the stated range.
By their numbers in this assay, from the lowest: compounds 3, 4 and 2 (each within the scatter of the next). At a limit, above all of these: compound 1.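

Compound 4 is the first of the compounds shown to differ on the phenyl group and not on the amide side, and in this assay the move from phenyl to 4-fluorophenyl gives a 1.1-fold higher number from compound 3 to compound 4 (0.04 log units; within the scatter). A fluoro para to a large group on this six-membered aromatic ring therefore leaves the number within the scatter, so this single change gives no sign that the read-out responds at this place. Nothing measured here bears on why that is so.

As far as these compounds go, whether an amine, a carboxylic acid or a methoxy group in place of the fluoro would move the number beyond the scatter stays open. Also open, from the compounds shown here alone, is whether the 4-fluorophenyl change would read the same with the 2-hydroxyphenyl amide of compound 2 instead of the cyclohexyl amide.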